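Trimming the Long Chain: Expected Lipophilicity of Compound 4

The source may hold more compounds than are shown below. What is called first, only, known or untested is meant among the compounds shown, and "the series" means these compounds.

Compound 2 `CCCCCCCCCCCCCCCCCCN1CCN(Cc2ccc(-c3noc(=O)[nH]3)cc2)CC1` and compound 1 `CCCCCCCCCCCCCCCCN1CCN(Cc2ccc(-c3noc(=O)[nH]3)cc2)CC1` share one core and differ only in the length of the saturated chain. In a physicochemical assay for lipophilicity (on this read-out higher numbers stand for higher lipophilicity and lower numbers for lower lipophilicity), compound 2 gives 7.37, while compound 1 gives 6.34; the change hydrogen in place of ethyl on a saturated chain carbon, ten or more bonds along the chain from an amine nitrogen in a ring brought a number 1.03 log units lower from compound 2 to compound 1 (beyond the scatter). Compound 3 `CCCCCCCCCCCCCCCCN1CCN(Cc2ccc(Cc3noc(=O)[nH]3)cc2)CC1` carries a different core, and the difference between the cores of compound 3 and compound 2 is not broken down here. In this assay compound 3 gives 6.63, which is a number 0.29 log units higher from compound 1 to compound 3 (within the scatter). Compound 4 `CCCCCCCCCCCCCCN1CCN(Cc2ccc(Cc3noc(=O)[nH]3)cc2)CC1` arises from compound 3 by the same change, (hydrogen in place of ethyl on a saturated chain carbon, ten or more bonds along the chain from an amine nitrogen in a ring). For compound 4 the expected step is a number 1.03 log units lower from compound 3 to compound 4 (beyond the scatter). This expectation rests on the earlier step, since that change gave a number 1.03 log units lower from compound 2 to compound 1 (beyond the scatter). Compound 4 is therefore estimated to give about 5.6 in this assay, expected to lie between 5.3 and 5.9.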

Compound 4, partition coefficient: 5.59
Compound 4: the middle estimate sits 0.01 log units above what was measured; low and high end bracket the measured number.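

In this assay the change from ethyl to hydrogen on the saturated chain gave a number 1.04 log units lower from compound 3 to compound 4 (beyond the scatter), and on the other core it gave a number 1.03 log units lower from compound 2 to compound 1 (beyond the scatter), so the step carried over between these two cores at much the same size. This rests on two pairs only, and the cores themselves sit close together, with a number 0.29 log units higher from compound 1 to compound 3 (within the scatter), so it does not show that the step would hold on a core that differs more. Nothing measured here explains the agreement.

As far as these compounds go, it stays open whether the same step would appear on a still shorter chain. From the compounds shown here alone, it is equally open whether it would survive with a carboxylic acid in place of the five-membered aromatic ring.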